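Swapping a benzyl for a pyrazolylmethyl on the amide nitrogen

The compounds below may be only part of what the source reports. "The series", "measured", "known", "first", "only" and "open" are said of these compounds alone.

Compound 2 `CCN(Cc1ccccc1)C(=O)COc1ccc(C)cc1` gives 1880 nM in an assay on HEK293 cells for agonist activity at transient receptor potential cation channel subfamily M member 8 (Homo sapiens), read by fluorescence and calcium flux, with a stated time of 15 min (a lower number here means that less compound is needed, a higher number that more compound is needed for the effect), which places it second highest of the three measured numbers. Its nearest neighbour is compound 3 `CCN(Cc1cccs1)C(=O)COc1ccc(C#N)cc1` at 1990 nM, a gap within the scatter, and the furthest is compound 1 `CCc1ccc(OCC(=O)N(CC)Cc2cccs2)cc1` at 67 nM. Within the data shown here, the one measured step that changes a single place is a 30-fold higher number from compound 1 to compound 3 (1.47 log units; beyond the scatter); it concerns the aromatic ring of the ether side and therefore does not bear on the change considered here. Compound 4 `CCN(Cc1cc[nH]n1)C(=O)COc1ccc(C)cc1` differs from compound 2 by 1H-pyrazol-3-yl in place of phenyl on a saturated chain carbon bound to an amide-type nitrogen. Among the measured compounds shown here, no measured pair isolates this exchange, and compound 1 and compound 2 differ in two places at once, so their two values cannot be read as a single step. The author therefore expects compound 4 to show a 1.3-fold higher number from compound 2 to compound 4 (0.12 log units; within the scatter), a change not expected to exceed the scatter, with wide uncertainty. The estimate for compound 4 is 2500 nM, between 500 nM and 15000 nM.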

Compound 4, half-maximal effective concentration: "not active" (no number reported)
For compound 4 the study gives words and no number, and the estimate cannot be compared.
By their numbers in this assay, from the lowest: compound 1; then compounds 2 and 3 (each within the scatter of the next).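

In this assay, among these compounds, compound 4 is reported only in words, as not active, so no step from compound 2 to compound 4 can be read. Nothing shown here accounts for this result. The compounds shown leave open how far benzyl to (1H-pyrazol-3-yl)methyl alone shifts the number.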